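This account rests on a few compounds, and the source may have more. Where it says the series, first, only, none or still open, it means among the compounds named here.

Among the compounds with values here, compound 2 `O=C(NCCCCc1ccccc1)c1cccc(C2SCC(=O)N2c2cccc(F)c2)c1` has the higher of the two numbers measured so far: in a functional assay on SJSA-1 cells (Homo sapiens) for inhibition, read by CCK-8 assay, with a stated time of 72 h, tested at 1 uM (a higher number here means more inhibition at the concentration tested (going by the name of the read-out), a lower number less inhibition), compound 2 gives 80%, which is the highest of the two numbers, and its nearest neighbour is compound 1 `COc1ccc(OC)c(N2C(=O)CSC2c2cccc(C(=O)NCCCCc3ccccc3)c2)c1`, which in this assay gives 48%. Within the data shown here, the one measured step joining these two, a number 32 percentage points higher from compound 1 to compound 2 (beyond the scatter), shows that exchanging a dimethoxyphenyl group for a fluorophenyl group on the amide-type nitrogen in the ring moved the read-out well beyond the scatter.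

Compound 3 `COc1cccc(OC)c1N1C(=O)CSC1c1cccc(C(=O)NCCCCc2ccccc2)c1` differs from compound 2 in a single change: 2,6-dimethoxyphenyl in place of 3-fluorophenyl on an amide-type nitrogen in a ring. This is the reverse kind of exchange to the measured step, in that a fluorophenyl group again gives way to a dimethoxyphenyl group, though the dimethoxyphenyl group of compound 3 is not the same one as that of compound 1. That measured step is the only one that bears on the change, and because it gave a number 32 percentage points higher from compound 1 to compound 2 (beyond the scatter), a step downward in this assay of roughly comparable size is expected here, with the caution that the substitution pattern differs.

For compound 3 the expected step in this assay is a number 30 percentage points lower from compound 2 to compound 3 (beyond the scatter). Compound 3 is therefore estimated to give 50% in this assay, within a range from 25% to 75%.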

Compound 3, a percentage reported as inhibition, at one concentration (the size of the read-out at that concentration, not a potency): 72%
For compound 3 the middle estimate is 22 percentage points below the measured one; the range from low to high includes it.
By their numbers in this assay, from the lowest: compound 1; then compounds 3 and 2 (each within the scatter of the next).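

In this assay, putting 2,6-dimethoxyphenyl in place of 3-fluorophenyl on the amide-type nitrogen gives a number 8 percentage points lower from compound 2 to compound 3 (within the scatter) and so leaves the two groups indistinguishable at this position, which means that carrying two methoxy groups on this phenyl ring does not by itself bring the low number of compound 1. The arrangement of those two methoxy groups does count among these compounds, since 2,6-dimethoxyphenyl in place of 2,5-dimethoxyphenyl, a change that keeps the same atoms and moves only the substituents, gives a number 24 percentage points higher from compound 1 to compound 3 (beyond the scatter) and thus separates two groups of identical composition. Nothing available explains why these two dimethoxyphenyl groups differ in this way.

The compounds shown leave open what a phenyl ring with a single methoxy group, or with an amine or a carboxylic acid, would give on this nitrogen, and whether 2,6-difluorophenyl would track 3-fluorophenyl. Going by these compounds, all three also share the same four-carbon chain ending in phenyl on the amide, so what a shorter chain would do alongside these groups remains unknown.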